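Removing a methyl from an oxygen: a small shift expected

This account rests on a few compounds, and the source may have more. Where it says the series, first, only, none or still open, it means among the compounds named here.

Compound 1 `COc1ccc(C2CC(Nc3nc4ccc(C)cc4s3)=NN2C(C)=O)cc1` was tested in a functional assay on the whole organism (Hindlimb, strain albino) with Mus musculus as the target, in the maximal electroshock model, with a stated time of 0.5 h (a higher number here means that more compound is needed for the effect, a lower number that less compound is needed), and compound 1 gives 37.3 umol/kg. Compound 2 `CC(=O)N1N=C(Nc2nc3ccc(C)cc3s2)CC1c1ccc(O)cc1` differs from compound 1 only by hydrogen in place of methyl on an oxygen on an aromatic ring, and in this assay compound 2 gives 50.2 umol/kg. That change made a 1.3-fold higher number from compound 1 to compound 2 (0.13 log units; within the scatter), so the two numbers cannot be told apart.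

Compound 3 `COc1ccc(/C=C/C(=O)Nc2nc3ccc(Cl)cc3s2)cc1` has a different core; how its core differs from that of compound 1 is not broken down here. In this assay compound 3 gives 259 umol/kg, the highest of the three numbers, beyond the scatter from both compound 1 and compound 2.

Compound 4 `O=C(/C=C/c1ccc(O)cc1)Nc1nc2ccc(Cl)cc2s1` has not yet been measured. It differs from compound 3 by hydrogen in place of methyl on an oxygen on an aromatic ring, the same change, at the same kind of place, as from compound 1 to compound 2. Because that earlier step was a 1.3-fold higher number from compound 1 to compound 2 (0.13 log units; within the scatter), the step from compound 3 to compound 4 is expected to be small as well, about a 1.2-fold higher number from compound 3 to compound 4 (0.09 log units; within the scatter). Compound 4 is therefore estimated at 320 umol/kg, between 150 umol/kg and 650 umol/kg.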

Compound 4, dose for half-maximal effect: 322 umol/kg
The estimate for compound 4 lay 1.0-fold (0.00 log units) below the measured number, within the range that was stated.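

Replacing methoxy with hydroxy on the aromatic ring gave a 1.2-fold higher number from compound 3 to compound 4 (0.09 log units; within the scatter), so in this assay the numbers for this pair cannot be told apart. The same held for the first pair, and the two steps agree with each other: the same change on two cores in this assay, a 1.3-fold higher number (0.13 log units; within the scatter) from compound 1 to compound 2 and a 1.2-fold higher number (0.09 log units; within the scatter) from compound 3 to compound 4, 1.1-fold (0.03 log units) apart, within the scatter of two such steps This shows that a small step on one core was matched by a small step on a second core, but it rests on just two pairs and does not show that the change would stay this small on any other core in the series, nor does it explain why so little happened.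

The compounds shown carry only methoxy or hydroxy at this place on the ring, so it remains open what a longer chain on the oxygen, such as ethoxy, or an amine in place of the oxygen would do. From the compounds shown here alone, whether methoxy to hydroxy behaves the same way in any test other than this assay also stays open.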